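Amide aryl variation on the shared flavonol-type core

The source may report more compounds than this note shows. Statements on the series, on what has been measured and on what is new or still open speak of the compounds shown alone.

Measured compounds, antiproliferative read-out:
- compound 1, `Cc1ccc(C(=O)Nc2cccc(-c3oc4cc(-c5ccc(F)cc5)ccc4c(=O)c3O)c2)cc1`: 12900 nM
- compound 2, `O=C(Nc1cccc(-c2oc3cc(-c4ccc(F)cc4)ccc3c(=O)c2O)c1)c1ccc(C(F)(F)F)cc1`: 33000 nM
- compound 3, `Cc1cccc(C(=O)Nc2cccc(-c3oc4cc(-c5ccc(F)cc5)ccc4c(=O)c3O)c2)c1`: 10900 nM

In a functional assay on GTL 16 cells for antiproliferative activity against GTL 16 cell line (Homo sapiens), read by CCK-8 assay, with a stated time of 72 h (on this read-out higher numbers stand for weaker inhibition and lower numbers for stronger inhibition), compound 3 gives the lowest number of the three, but its gap to compound 1 is within the scatter, as a 1.2-fold lower number from compound 1 to compound 3 (0.07 log units; within the scatter) shows; only compound 2 stands clearly apart, with a 3.0-fold lower number from compound 2 to compound 3 (0.48 log units; beyond the scatter).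

Compound 4, `O=C(Nc1cccc(-c2oc3cc(-c4ccc(F)cc4)ccc3c(=O)c2O)c1)c1cccc(F)c1`, differs from compound 3 by fluoro in place of methyl on an aromatic carbon.

Within the data shown here, two measured steps bear on this change. Replacing methyl with a fluorine-bearing group on the amide aryl ring gave a 2.6-fold higher number from compound 1 to compound 2 (0.41 log units; beyond the scatter), and moving the methyl from one ring position to another gave a 1.2-fold lower number from compound 1 to compound 3 (0.07 log units; within the scatter). Among the measured compounds shown here, no measured step shows a single fluoro in place of methyl, so the direction is taken from the trifluoromethyl case, scaled down for the smaller group.

Compound 4 is therefore expected to give a slightly higher number than compound 3, a step of a 1.3-fold higher number from compound 3 to compound 4 (0.11 log units; within the scatter), most likely within the scatter. The estimate for compound 4 in this assay is 14000 nM, with a range of 7000 nM to 30000 nM.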

Compound 4, half-maximal inhibitory concentration: 15800 nM
Estimate against measurement, compound 4: 1.1-fold (0.05 log units) below; low and high end bracket the measured number.
By their numbers in this assay, from the lowest: compounds 3, 1 and 4 (each within the scatter of the next); then compound 2.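

In this assay, among these compounds, the first direct reading of fluoro in place of methyl on this aromatic carbon, meta to a large group, is a 1.4-fold higher number from compound 3 to compound 4 (0.16 log units; within the scatter). The 3-fluorophenyl amide is likewise not separated from the 4-methylphenyl amide, with a 1.2-fold higher number from compound 1 to compound 4 (0.09 log units; within the scatter). Compound 2 alone stands apart from it, with a 2.1-fold lower number from compound 2 to compound 4 (0.32 log units; beyond the scatter), so 3-methylphenyl, 4-methylphenyl and 3-fluorophenyl cannot be told apart here, and only 4-(trifluoromethyl)phenyl differs; nothing at hand accounts for the size of these steps.

The step from compound 2 to compound 4 changes both the group and its place on the ring, so the two contributions cannot be separated. Also open, from the compounds shown here alone, is whether an amine or a carboxylic acid on this ring would move the number beyond the scatter from compound 3.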